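This account rests on a few compounds, and the source may have more. Where it says the series, first, only, none or still open, it means among the compounds named here.

Measured in a toxicity assay on THP-1 cells (Homo sapiens) for inhibition; a lower number here means that less compound is tolerated, a higher number that more compound is tolerated:
Compound 1 `Cn1c(-c2ccccc2)cnc1NC(=O)c1ccc(Cl)cc1`: > 100000 nM (a limit)
Compound 2 `Cn1c(-c2ccccc2)cnc1NC(=O)c1ccc(Br)cc1`: > 100000 nM (a limit)

In this assay compound 2 stands at > 100000 nM, which is a limit and not a number. Compound 3 `Cn1c(-c2ccccc2)cnc1NC(=O)c1ccccc1Cl` carries 2-chlorophenyl in place of 4-bromophenyl on a carbonyl carbon. Within the data shown here, the only measured step, a step that the two limits leave unreadable from compound 1 to compound 2, offers no size to carry over. The expectation therefore rests on (the limit of > 100000 nM in this assay, at which 2 of the 2 values shown sit). An estimated a number no higher from compound 2 to compound 3 (the limit leaves the size open) is expected, with no direction that the data can supply. Compound 3 is expected at 100000 nM, with an estimated range of 40000 nM to 200000 nM, and most likely again as a limit.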

Compound 3, half-maximal cytotoxic concentration: > 50000 nM
Compound 3: a limit, no number; the forecaster's own chance of this, stated with the estimate: 80%; the middle value lies beyond the limit too.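

In this assay, among these compounds, compound 1, compound 2 and compound 3 all give limits, not numbers, so no step among them can be read. As far as these compounds go, the half-maximal cytotoxic concentration of each compound remains open, as does any difference between them.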